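The compounds below may be only part of what the source reports. "The series", "measured", "known", "first", "only" and "open" are said of these compounds alone.

In an ADME assay on HeLa cells (Homo sapiens) for inhibition, read by MTT assay, with a stated time of 72 h (on this read-out higher numbers stand for weaker inhibition of growth and lower numbers for stronger inhibition of growth), three compounds have been measured so far:
compound 1 `O=C(CC(=O)c1ccccc1O)c1cc2ccccc2s1` gives 7.86 ug/mL;
compound 2 `O=C(CC(=O)c1cc(Cl)ccc1O)c1cc2ccccc2s1` gives 4.42 ug/mL;
compound 3 `Cc1ccc(O)c(C(=O)CC(=O)c2cc3ccccc3s2)c1` gives 7.12 ug/mL.

The three numbers lie close together. Compound 1 gives the largest of them, but the gap a 1.1-fold lower number from compound 1 to compound 3 (0.04 log units; within the scatter) and the gap a 1.8-fold lower number from compound 1 to compound 2 (0.25 log units; within the scatter) both stay within the scatter, so no real ordering can be read from them.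

Compound 4 `Cc1ccc(C(=O)CC(=O)c2cc3ccccc3s2)c(O)c1` differs from compound 1 by methyl in place of hydrogen on an aromatic carbon. Going by the values given here, the closest precedent is a methyl likewise placed on an aromatic carbon, seen in the step of a 1.1-fold lower number from compound 1 to compound 3 (0.04 log units; within the scatter). The other two steps, a 1.8-fold lower number from compound 1 to compound 2 (0.25 log units; within the scatter) and a 1.6-fold higher number from compound 2 to compound 3 (0.21 log units; within the scatter), also remained within the scatter. On this basis the expected step in this assay is a 1.1-fold lower number from compound 1 to compound 4 (0.05 log units; within the scatter), that is, nothing beyond the scatter in either direction. Compound 4 is therefore estimated at 7 ug/mL, with a range from 3.5 ug/mL to 14 ug/mL.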

Compound 4, concentration for 50% growth inhibition: 23.1 ug/mL
Compound 4: the middle estimate sits 3.3-fold (0.52 log units) below what was measured; the measured number lies above the stated range.
By their numbers in this assay, from the lowest: compounds 2, 3 and 1 (each within the scatter of the next); then compound 4.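

In this assay, methyl in place of hydrogen, meta to a hydroxy group and para to a large group, gives a step beyond the scatter (a 2.9-fold higher number from compound 1 to compound 4 (0.47 log units; beyond the scatter)). The same replacement at another carbon of that ring stayed within the scatter (a 1.1-fold lower number from compound 1 to compound 3 (0.04 log units; within the scatter)), so for these two compounds the outcome depends on where the methyl sits. Nothing available explains this difference.

As far as these compounds go, whether any group at this carbon raises the number, or only methyl does, remains open. A methoxy group or an amine there would begin to test this.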